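A Second Fluoro Group on an Aromatic Ring

The source may report more compounds than this note shows. Statements on the series, on what has been measured and on what is new or still open speak of the compounds shown alone.

Compound 1 `O=S(=O)(c1cccc(F)c1)c1cnc2c(F)cccc2c1-c1cccc(F)c1` and compound 2 `O=S(=O)(c1cc(F)cc(F)c1)c1cnc2c(F)cccc2c1-c1cccc(F)c1` share one core. In an ADME assay on microsomes from liver (Homo sapiens) for metabolic stability, tested at 2.5 uM (a lower number here means slower removal, a higher number faster removal of the compound), compound 1 gives 1.14 mL/min and compound 2 gives 1.18 mL/min. The change between them, (fluoro in place of hydrogen on an aromatic carbon), produced a 1.0-fold higher number from compound 1 to compound 2 (0.01 log units; within the scatter). Compound 3 `O=S(=O)(c1ccc(F)cc1)c1cnc2c(F)cccc2c1-c1cccc(Cl)c1` gives 1.21 mL/min in this assay; the difference between its core and that of compound 1 is not broken down here. Compound 4 `O=S(=O)(c1ccc(F)c(F)c1)c1cnc2c(F)cccc2c1-c1cccc(Cl)c1` has not been measured yet and differs from compound 3 by fluoro in place of hydrogen on an aromatic carbon. Among the compounds with values here, this is the same kind of change as the one from compound 1 to compound 2, though the place differs: in compound 4 the entering fluoro group sits ortho to a fluoro group, while in compound 2 it sits meta to a fluoro group. Because the earlier step gave a 1.0-fold higher number from compound 1 to compound 2 (0.01 log units; within the scatter), compound 4 is expected to show a 1.0-fold lower number from compound 3 to compound 4 (0.00 log units; within the scatter). Compound 4 is estimated at 1.2 mL/min, with a range from 0.8 mL/min to 1.8 mL/min.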

Compound 4, intrinsic clearance in a liver preparation (reported as CLH), per the amount of preparation that the assay uses: 1.13 mL/min
For compound 4 the middle estimate is 1.1-fold (0.03 log units) above the measured one; the range from low to high includes it.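

Replacing the 4-fluorophenyl group with a 3,4-difluorophenyl group gave a 1.1-fold lower number from compound 3 to compound 4 (0.03 log units; within the scatter) in this assay. Set beside the earlier fluoro step, the change reads the same on both cores: the same change on two cores in this assay, a 1.0-fold higher number (0.01 log units; within the scatter) from compound 1 to compound 2 and a 1.1-fold lower number (0.03 log units; within the scatter) from compound 3 to compound 4, 1.1-fold (0.04 log units) apart, within the scatter of two such steps. This shows that adding this fluoro group made no measurable difference on either of these two cores, even though it entered at a different place on each, but two small steps do not make a rule for other cores in the series, and they do not explain the result.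

As far as these compounds go, it remains open whether a larger entering group, such as a methoxy group or an amine, would also leave the number in this assay unmoved. The same question stands for a fluoro group entering on the other aromatic rings.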